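The source may hold more compounds than are shown below. What is called first, only, known or untested is meant among the compounds shown, and "the series" means these compounds.

Measured so far in an assay on HEK293 cells for inhibition of Steryl-sulfatase (Homo sapiens), tested at 1 uM; a higher number here means a stronger effect of the compound at the concentration tested, a lower number a weaker effect:

Compound 1 `CCN(Cc1ccncc1)c1ccc(C(=O)N2CCc3ccc(OS(N)(=O)=O)cc3C2)cc1` gives 86.6%.
Compound 2 `CCN(Cc1ccncc1)c1cccc(C(=O)N2CCc3ccc(OS(N)(=O)=O)cc3C2)c1` gives 52.8%.
Compound 3 `CCN(Cc1ccc(F)cc1)c1ccc(C(=O)N2CCc3ccc(OS(N)(=O)=O)cc3C2)cc1` gives 91.2%.

Compound 1 and compound 2 are built from the same atoms joined differently; the difference between the two cores is not broken down here. Compound 2 has the lowest of the three numbers. Compound 3 differs from compound 1 by 4-fluorophenyl in place of pyridin-4-yl on a saturated chain carbon bound to a nitrogen on an aromatic ring, and in this assay that change gave a number 4.6 percentage points higher from compound 1 to compound 3 (within the scatter).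

Compound 4 `CCN(Cc1ccc(F)cc1)c1cccc(C(=O)N2CCc3ccc(OS(N)(=O)=O)cc3C2)c1` differs from compound 2 by 4-fluorophenyl in place of pyridin-4-yl on a saturated chain carbon bound to a nitrogen on an aromatic ring, the same change placed on the core of compound 2. The step expected here is a number 4.2 percentage points higher from compound 2 to compound 4 (within the scatter), a step expected to stay within the scatter. This rests on compound 1, because a number 4.6 percentage points higher from compound 1 to compound 3 (within the scatter) shows the same change hardly moved the number. Compound 4 is estimated at about 57%, expected between 42% and 72%.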

Compound 4, a percentage reported as inhibition, at one concentration (the size of the read-out at that concentration, not a potency): 66.5%
Compound 4: middle estimate off by 9.5 percentage points, on the low side; the range from low to high includes it.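

On the core of compound 2, 4-fluorophenyl in place of pyridin-4-yl gave a number 13.7 percentage points higher from compound 2 to compound 4 (beyond the scatter) in this assay. Set beside the same change on the core of compound 1, the two steps cannot be told apart: the same change on two cores in this assay, a number 4.6 percentage points higher (within the scatter) from compound 1 to compound 3 and a number 13.7 percentage points higher (beyond the scatter) from compound 2 to compound 4, 9.1 percentage points apart, within the scatter of two such steps. The change therefore carried from one core to the other with no size difference that can be distinguished from scatter, but two cores cannot show that it would behave alike on further cores, nor that the two steps are truly equal.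

The compounds shown leave open what a plain phenyl or a pyridin-3-yl would give on the same chain carbon. A longer chain in place of the ethyl on the nitrogen also remains an open question.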